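Three measured analogs and a fourth awaiting its cytotoxicity read-out

This account rests on a few compounds, and the source may have more. Where it says the series, first, only, none or still open, it means among the compounds named here.

Compound 1 `COc1cccc(CNCCCNc2ccnc3cc(Oc4ccc(Cl)cc4)ccc23)c1O`: 5700 nM
Compound 2 `COc1cccc(CNCCCNc2ccnc3cc(-c4ccccc4)ccc23)c1O`: 3210 nM
Compound 3 `COc1cccc(CNCCCNc2ccnc3cc(Cc4ccc(F)cc4)ccc23)c1O`: 4780 nM

In an ADME assay on HepG2 cells (Homo sapiens) for cytotoxicity, read by luminescence, CellTiter-Glo and ATP content, with a stated time of 72 h (on this read-out lower numbers stand for an effect already at smaller amounts and higher numbers for an effect only at larger amounts of compound), compound 3 gives 4780 nM, the second highest of the three numbers; one step is a 1.2-fold lower number from compound 1 to compound 3 (0.08 log units; within the scatter) and another is a 1.5-fold higher number from compound 2 to compound 3 (0.17 log units; within the scatter), both within the scatter. Compound 4 `COc1cccc(CNCCCNc2ccnc3cc(Cc4cc(C)cc(C)c4)ccc23)c1O` differs from compound 3 by 3,5-dimethylphenyl in place of 4-fluorophenyl on a saturated chain carbon bound to an aromatic carbon. For the measured compounds named here, the steps that bear on this change are those varying the group on the same aromatic carbon of the shared core: a 1.8-fold lower number from compound 1 to compound 2 (0.25 log units; within the scatter), a 1.2-fold lower number from compound 1 to compound 3 (0.08 log units; within the scatter) and a 1.5-fold higher number from compound 2 to compound 3 (0.17 log units; within the scatter), none beyond the scatter. Compound 4 is therefore expected to show no step beyond the scatter, a 1.1-fold lower number from compound 3 to compound 4 (0.03 log units; within the scatter). The estimate for compound 4 is 4500 nM, with a range from 2000 nM to 10000 nM.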

Compound 4, half-maximal effective concentration: 2680 nM
Estimate against measurement, compound 4: 1.7-fold (0.23 log units) above; low and high end bracket the measured number.
By their numbers in this assay, from the lowest: compounds 4, 2, 3 and 1 (each within the scatter of the next, the first and the last beyond it).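

In this assay, 3,5-dimethylphenyl in place of 4-fluorophenyl on a saturated chain carbon bound to an aromatic carbon stays within the scatter (a 1.8-fold lower number from compound 3 to compound 4 (0.25 log units; within the scatter)), and so does the comparison with the phenyl analog (a 1.2-fold lower number from compound 2 to compound 4 (0.08 log units; within the scatter)). The comparison with the 4-chlorophenoxy analog (a 2.1-fold lower number from compound 1 to compound 4 (0.33 log units; beyond the scatter)) is the only step among these compounds to pass the scatter, and it is modest. Nothing available explains these numbers.

The compounds shown leave open whether an amine, a carboxylic acid or a longer chain on this aromatic carbon of the shared core would give a step beyond the scatter from compound 2 or compound 3.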